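Side-chain variation on a shared core: compounds 1 to 4

This account rests on a few compounds, and the source may have more. Where it says the series, first, only, none or still open, it means among the compounds named here.

Compound 1, `CCC/C=C/C=C/c1cc(C#N)ccc1COC(c1ccc(C#N)cc1)c1cncn1C`: in a functional assay on NIH3T3 cells (Mus musculus) (a higher number here means that more compound is needed for the effect, a lower number that less compound is needed), compound 1 gives 16.7 nM.
Compound 2, `Cn1cncc1C(OCc1ccc(C#N)cc1-c1ccc(-c2ccccc2)cc1)c1ccc(C#N)cc1`: in this assay compound 2 reaches only a limit, < 0.1 nM.
Compound 3, `Cn1cncc1C(OCc1ccc(C#N)cc1C#CC(C)(C)C)c1ccc(C#N)cc1`: in this assay compound 3 gives 76.9 nM.

Among the two actual numbers, compound 1 stands lowest; its nearest neighbour is compound 3, with a 4.6-fold higher number from compound 1 to compound 3 (0.66 log units; beyond the scatter). Compound 2 sits at the limit of < 0.1 nM in this assay, at which 1 of the 3 values shown sits, so its value is a limit rather than a number. The steps from it are read accordingly: an at least 160-fold lower number from compound 1 to compound 2 (2.22 log units; beyond the scatter) and an at least 760-fold higher number from compound 2 to compound 3 (2.88 log units; beyond the scatter).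

Compound 4, `Cn1cncc1C(OCc1ccc(C#N)cc1C#CCCc1ccccc1)c1ccc(C#N)cc1`, differs from compound 1 at one place: 4-phenylbut-1-yn-1-yl in place of hepta-1,3-dien-1-yl on an aromatic carbon.

Among the compounds with values here, two measured steps bear on this change. Replacing hepta-1,3-dien-1-yl by a group with a triple bond outside aromatic rings gave the modest rise seen in a 4.6-fold higher number from compound 1 to compound 3 (0.66 log units; beyond the scatter), while replacing it by a group with an aromatic ring gave the large drop in an at least 160-fold lower number from compound 1 to compound 2 (2.22 log units; beyond the scatter). The entering 4-phenylbut-1-yn-1-yl carries both a triple bond and a six-membered aromatic ring, so the expected outcome lies between these two, leaning toward a lower number.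

Compound 4 is therefore expected to give about 4 nM, with a range from 0.4 nM to 40 nM. For compound 4 the estimated step is a 4.2-fold lower number from compound 1 to compound 4 (0.62 log units; beyond the scatter).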

Compound 4, half-maximal effective concentration: 130 nM
Compound 4: middle estimate off by 33-fold (1.51 log units), on the low side; the whole stated range lies below it.
By their numbers in this assay, from the lowest: compound 1; then compounds 3 and 4 (each within the scatter of the next). At a limit, below all of these: compound 2.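

On this aromatic carbon, a six-membered aromatic ring in the side chain does not by itself bring a low number: 4-phenylbut-1-yn-1-yl in place of hepta-1,3-dien-1-yl gives a 7.8-fold higher number from compound 1 to compound 4 (0.89 log units; beyond the scatter), in the same direction as the step to the 3,3-dimethylbut-1-yn-1-yl group of compound 3. Between the two triple-bonded side chains, phenethyl in place of tert-butyl on the triple-bonded carbon gives a 1.7-fold higher number from compound 3 to compound 4 (0.23 log units; within the scatter), so in this assay this exchange does not separate the two compounds. Compound 2 remains far apart from the triple-bonded pair, with an at least 1300-fold higher number from compound 2 to compound 4 (3.11 log units; beyond the scatter), and its value is a limit rather than a number: the limit of < 0.1 nM in this assay, at which 1 of the 4 values shown sits.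

The compounds shown leave open whether the low limit of compound 2 goes with the first ring on the aromatic carbon or needs the second one, a question that a plain phenyl group at this place would address. They also leave open whether the triple bond itself matters, since a saturated chain such as 4-phenylbutyl would carry the same phenyl group without it.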